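This account rests on a few compounds, and the source may have more. Where it says the series, first, only, none or still open, it means among the compounds named here.

Measured compounds:
compound 1, `ClCc1ccccc1Cn1cnc2c(Cl)nc(Cl)nc21`: 360 nM
compound 2, `ClCc1cccc(Cn2cnc3c(Cl)nc(Cl)nc32)c1`: 3380 nM
compound 3, `Nc1nc(Cl)c2ncn(Cc3ccccc3CCl)c2n1`: 21900 nM

In a functional assay on LOX IMVI cells (Homo sapiens) for cytotoxicity, read by sulforhodamine B assay, with a stated time of 48 h (a higher number here means a weaker inhibitor of growth, a lower number a stronger inhibitor of growth), compound 1 gives 360 nM, the lowest number among the three measured compounds. Compound 2 has the same atoms as compound 1, joined differently; the difference between the two cores is not broken down here. In this assay compound 2 gives 3380 nM, which stands above compound 1 and below compound 3, both gaps lying beyond the scatter. Compound 3 differs from compound 1 in one place, (amino in place of chloro on an aromatic carbon), and the step is a 61-fold higher number from compound 1 to compound 3 (1.78 log units; beyond the scatter). In this assay compound 3 gives 21900 nM, the highest number of the three.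

Compound 4, `Nc1nc(Cl)c2ncn(Cc3cccc(CCl)c3)c2n1`, has not yet been measured. It differs from compound 2 by amino in place of chloro on an aromatic carbon. This is the same change as the one from compound 1 to compound 3, the surroundings of the place being identical, and it occurs twice among the compounds shown. For the measured compounds named here, the expected step from compound 2 to compound 4 is a 36-fold higher number from compound 2 to compound 4 (1.55 log units; beyond the scatter), and it rests on the single earlier example a 61-fold higher number from compound 1 to compound 3 (1.78 log units; beyond the scatter). That step is applied to the starting point of compound 2, which gives 3380 nM. Going by the values given here, with only one prior instance the uncertainty is wide, and a number so high may fall outside what the assay can report. In this assay compound 4 is therefore expected to give about 120000 nM, estimated to lie between 30000 nM and 400000 nM.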

Compound 4, concentration for total growth inhibition: 13200 nM
Compound 4: middle estimate off by 9.1-fold (0.96 log units), on the high side; the whole stated range lies above it.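

In this assay the change of amino in place of chloro on an aromatic carbon moves the number in the same direction on the core of compound 2 as on the core of compound 1, here with a 3.9-fold higher number from compound 2 to compound 4 (0.59 log units; beyond the scatter), so the direction of the step carries over between these two cores. The size of the step does not carry over, since the two steps lie further apart than the scatter of two such steps: the same change on two cores in this assay, a 61-fold higher number (1.78 log units; beyond the scatter) from compound 1 to compound 3 and a 3.9-fold higher number (0.59 log units; beyond the scatter) from compound 2 to compound 4, 16-fold (1.19 log units) apart, beyond the scatter of two such steps. For the compounds shown here, this shows that the effect of the change on the number depends on the core it is made on, but with only two cores it does not show what sets the size of the step, and it gives no rule for how large the step would be on a further core.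

The compounds shown leave open whether other groups on the same aromatic carbon, such as a methylamino group, a methoxy group or a fluoro group, would raise the number as amino does, and whether the gap between the two cores would persist with them. They also leave open whether the two cores would keep this difference in the size of the step in cell lines other than the one tested here.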